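Ester-to-amide swap and solubility across two cores

The source may hold more compounds than are shown below. What is called first, only, known or untested is meant among the compounds shown, and "the series" means these compounds.

Compound 1 `COC(=O)c1cccc(NC(=O)c2cc3cc([N+](=O)[O-])ccc3s2)c1` and compound 2 `NC(=O)c1cccc(NC(=O)c2cc3cc([N+](=O)[O-])ccc3s2)c1` share one core; compound 3 `COC(=O)c1cccc(NC(=O)c2ccc(-c3ccccc3)cc2)c1` and compound 4 `NC(=O)c1cccc(NC(=O)c2ccc(-c3ccccc3)cc2)c1` share another. How the two cores differ is not broken down here. In a physicochemical assay for solubility (on this read-out higher numbers stand for higher solubility and lower numbers for lower solubility), compound 1 gives 25 ug/mL. In this assay compound 2 gives 25 ug/mL. The change from compound 1 to compound 2 is amino in place of methoxy on a carbonyl carbon, and the step it made is no change at the digits printed from compound 1 to compound 2 (within the scatter). For compound 3 this assay reports only a limit, < 5 ug/mL, not a number; this is the limit of < 5 ug/mL in this assay, at which 1 of the 3 values shown sits.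

Compound 4 carries the same change on the second core: amino in place of methoxy on a carbonyl carbon. The place is the same as for the first pair, a carbonyl carbon whose other neighbour is an aromatic carbon, so this is the same change, not merely the same kind. On the first core that change moved nothing in this assay, as no change at the digits printed from compound 1 to compound 2 (within the scatter) shows, and the expectation is that it moves nothing on the second core either. The step from compound 3 to compound 4 in this assay is therefore expected to be a step that the limit leaves unreadable from compound 3 to compound 4, which rests on the flat step no change at the digits printed from compound 1 to compound 2 (within the scatter). Compound 4 is expected to give about 4 ug/mL in this assay, with a range from 1.5 ug/mL to 12 ug/mL, and it is likely that the assay again returns only a limit, because compound 3 already sits at the limit of < 5 ug/mL in this assay, at which 1 of the 3 values shown sits. Among the compounds with values here, only two pairs are in hand, so the flatness of this change is not established beyond them.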

Compound 4, solubility: 25 ug/mL
The estimate for compound 4 lay 6.3-fold (0.80 log units) below the measured number; the measured number lies above the stated range.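

In this assay, amino in place of methoxy on a carbonyl carbon gave no change at the digits printed from compound 1 to compound 2 (within the scatter) on the first core, and on the second core the same change gave an at least 5.0-fold higher number from compound 3 to compound 4 (0.69 log units; beyond the scatter). The second step gives only a lower bound on size, because compound 3 is reported as a limit and not as a number: the limit of < 5 ug/mL in this assay, at which 1 of the 4 values shown sits. Carrying this change between the two cores therefore did not carry its outcome, since the flat step on the first core did not recur on the second, but these two pairs do not show which difference between the cores accounts for this, how large the true step on the second core is, or whether either step would hold on any further core.

Open in these notes is how other groups on the same carbonyl carbon would read out in this assay on each core, for example a hydroxyl group, which would give a carboxylic acid, or an ester with a longer chain than methoxy. Also open, going by these compounds, is whether a dimethylamino group there would follow the step on the first core, the step on the second core, or neither.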